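Removing the methoxy from compound 3

This account rests on a few compounds, and the source may have more. Where it says the series, first, only, none or still open, it means among the compounds named here.

In a functional assay on HCC827 cells (Homo sapiens) for inhibition, read by fluorescence, with a stated time of 72 h (a higher number here means a weaker inhibitor of growth, a lower number a stronger inhibitor of growth), compound 1 (`CCCCCCn1cnc2c(Nc3ccc(Cl)cc3)nc(N[C@H]3CC[C@H](N)CC3)nc21`) gives 11700 nM and compound 2 (`N[C@H]1CC[C@H](Nc2nc(Nc3ccc(Cl)cc3)c3ncn(C4CCCCC4)c3n2)CC1`) gives 9100 nM. Compound 3 (`COc1ccc(Cn2cnc3c(Nc4cccc(Cl)c4)nc(N[C@H]4CC[C@H](N)CC4)nc32)cc1`) gives 18700 nM. This number is higher than that of compound 2, by a gap beyond the scatter, but lies within the scatter of compound 1.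

Compound 4 (`N[C@H]1CC[C@H](Nc2nc(Nc3cccc(Cl)c3)c3ncn(Cc4ccccc4)c3n2)CC1`) has hydrogen in place of methoxy on an aromatic carbon, para to a large group, so that 4-methoxybenzyl becomes benzyl: hydrogen in place of methoxy on an aromatic carbon.

Within the data shown here, no measured pair tests this methoxy directly. Among the measured compounds shown here, the nearest evidence is the only measured step, a 1.3-fold lower number from compound 1 to compound 2 (0.11 log units; within the scatter), which also changes a group on an aromatic nitrogen and stays within the scatter. On that single step, this assay is expected to show no change beyond the scatter, with a slight lean towards the lower numbers of the series. The estimated step is a 1.3-fold lower number from compound 3 to compound 4 (0.13 log units; within the scatter). For compound 4 the expected value is 14000 nM, with an estimated range of 7000 nM to 28000 nM.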

Compound 4, concentration for 50% growth inhibition: 13700 nM
Compound 4: the middle estimate sits 1.0-fold (0.01 log units) above what was measured; the range from low to high includes it.
By their numbers in this assay, from the lowest: compounds 2, 1, 4 and 3 (each within the scatter of the next, the first and the last beyond it).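

Among these compounds, the step from 4-methoxybenzyl to benzyl is the first direct test at this position: in this assay it gives a 1.4-fold lower number from compound 3 to compound 4 (0.14 log units; within the scatter), so the two compounds are not separated. The methoxy on this aromatic carbon is therefore not required for the growth inhibition seen with compound 3, and compound 4 keeps it without that group. No measurement shown gives a reason for this outcome.

As far as these compounds go, it remains open whether a different group on this same carbon, such as an amine or a carboxylic acid, would move the number beyond the scatter. Compound 4 also differs from compound 1 and compound 2 in more than one place, so the benzyl group cannot yet be compared directly with hexyl or cyclohexyl on the aromatic nitrogen.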